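This account rests on a few compounds, and the source may have more. Where it says the series, first, only, none or still open, it means among the compounds named here.

In an assay on isolated protein for inhibition of ubiquitin carboxyl-terminal hydrolase 7 (Homo sapiens), with stated times of 30 min and 2 h (on this read-out higher numbers stand for weaker inhibition and lower numbers for stronger inhibition), compound 1 `Cn1nc2c(=O)n(CC3(O)CCN(Cc4ccc(C5CCCO5)cc4Cl)CC3)cnc2c1-c1ccc(CN)cc1` gives 3820 nM, while compound 2 `Cn1cc(-c2ccc(CN3CCC(O)(Cn4cnc5c(-c6ccc(CN)cc6)n(C)nc5c4=O)CC3)c(Cl)c2)cn1` gives 291 nM, the lowest of the two numbers. Among the compounds with values here, the only measured step, a 13-fold lower number from compound 1 to compound 2 (1.12 log units; beyond the scatter), lies beyond the scatter. Compound 3 `Cn1nc2c(=O)n(CC3(O)CCN(Cc4ccc(-c5ccoc5)cc4Cl)CC3)cnc2c1-c1ccc(CN)cc1` differs from compound 2 by furan-3-yl in place of 1-methyl-1H-pyrazol-4-yl on an aromatic carbon. Within the data shown here, no measured step covers this exchange; the one step that exists swapped an oxolan-2-yl for a five-membered aromatic ring, and furan-3-yl, like the group it replaces, is itself a five-membered aromatic ring. A modest rise is therefore expected. The number for compound 3 is estimated at 700 nM, between 250 nM and 2000 nM, an expected step of a 2.4-fold higher number from compound 2 to compound 3 (0.38 log units; beyond the scatter).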

Compound 3, half-maximal inhibitory concentration: 177 nM
The estimate for compound 3 lay 4.0-fold (0.60 log units) above the measured number; the measured number lies below the stated range.
By their numbers in this assay, from the lowest: compounds 3 and 2 (each within the scatter of the next); then compound 1.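

Furan-3-yl in place of 1-methyl-1H-pyrazol-4-yl, on the aromatic carbon meta to the chloro group, gives a 1.6-fold lower number from compound 2 to compound 3 (0.22 log units; within the scatter), so these two five-membered aromatic rings cannot be told apart here. Furan-3-yl in place of oxolan-2-yl gives a 22-fold lower number from compound 1 to compound 3 (1.33 log units; beyond the scatter), which shows that the large step from the oxolan-2-yl compound does not depend on 1-methyl-1H-pyrazol-4-yl alone. Nothing available explains this result. From the compounds shown here alone, it remains open whether a phenyl or pyridinyl ring, or an amine such as morpholine, would give a number like those of compound 2 and compound 3.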